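This account rests on a few compounds, and the source may have more. Where it says the series, first, only, none or still open, it means among the compounds named here.

Compound 2 `CNc1ncc(C(=O)O)c2nc(-c3ccco3)nn12` is assessed in a functional assay on CHO cells for antagonist activity at adenosine receptor A2b (Homo sapiens); on this read-out higher numbers stand for weaker inhibition and lower numbers for stronger inhibition. In this assay compound 2 gives only a limit, > 10000 nM. Compound 1 `O=C(Nc1ncc(C(=O)O)c2nc(-c3ccco3)nn12)NC1CCCCC1`, which carries a cyclohexylcarbamoyl in place of the methyl, likewise gives only a limit in this assay, > 30000 nM. The step that the two limits leave unreadable from compound 1 to compound 2 cannot be read, as both values rest on limits (the limit of > 10000 nM in this assay, at which 1 of the 2 values shown sits, and (the limit of > 30000 nM in this assay, at which 1 of the 2 values shown sits)). Compound 3 `CCNc1ncc(C(=O)O)c2nc(-c3ccco3)nn12` differs from compound 2 by methyl in place of hydrogen on a saturated chain carbon bound to a nitrogen on an aromatic ring. Going by the values given here, no measured step bears on this change, and compound 2 is itself only bounded, so no shift beyond the scatter is expected. The estimated step is a step that the limit leaves unreadable from compound 2 to compound 3. Compound 3 is expected to give about 20000 nM, with a range from 8000 nM to 60000 nM.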

Compound 3, inhibition constant: > 10000 nM
Compound 3: a limit, no number; the forecaster's own chance of this, stated with the estimate: 80%; the middle value lies beyond the limit too.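

Compound 3 also gives only a limit in this assay, so its steps from compound 1 and compound 2 cannot be read. The compounds shown leave open how strongly any of the three inhibits in this assay.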